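The compounds below may be only part of what the source reports. "The series", "measured", "known", "first", "only" and "open" are said of these compounds alone.

Two compounds of the series have numbers in an assay on membranes from HEK293 cells for displacement of a labelled ligand from adenosine receptor A2b (Homo sapiens), read by scintillation counting, with a stated time of 30 min, tested at 1 uM; on this read-out higher numbers stand for more inhibition at the one concentration tested (going by the name of the read-out) and lower numbers for less inhibition. Compound 1 `CCCOC(=O)C1=C(C)N(C)C(=O)NC1c1ccco1` gives 23%. Among the measured compounds shown here, compound 2 `CC1=C(C(=O)OC(C)(C)C)C(c2ccco2)NC(=O)N1C` gives 26%; on the two numbers so far compound 2 sits alongside compound 1, since the step of a number 3 percentage points higher from compound 1 to compound 2 (within the scatter) lies within the scatter, so neither compound can be called the stronger. Compound 3 `CC1=C(C(=O)OC(C)(C)C)C(c2cccs2)NC(=O)N1C` is the next member to be measured in this assay: thiophen-2-yl in place of furan-2-yl on a saturated ring carbon. For the measured compounds named here, no measured step bears on this change; the one step available, a number 3 percentage points higher from compound 1 to compound 2 (within the scatter), concerns tert-butyl in place of propyl on an oxygen next to a carbonyl group and says nothing about the five-membered aromatic ring on the saturated ring carbon. The expectation for compound 3 in this assay is therefore a number near that of compound 2, with a step of a number 4 percentage points higher from compound 2 to compound 3 (within the scatter) that is not expected to exceed the scatter. Compound 3 is estimated at 30%, within the range 10% to 50%.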

Compound 3, a percentage reported as inhibition, at one concentration (the size of the read-out at that concentration, not a potency): 24%
Compound 3: middle estimate off by 6 percentage points, on the high side, within the range that was stated.
By their numbers in this assay, from the lowest: compounds 1, 3 and 2 (each within the scatter of the next).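

The saturated ring carbon now has its first measured step in this assay: with the tert-butoxycarbonyl group held constant, thiophen-2-yl in place of furan-2-yl gives a number 2 percentage points lower from compound 2 to compound 3 (within the scatter). At this position, exchanging the oxygen of the five-membered aromatic ring for sulfur therefore leaves compound 2 and compound 3 indistinguishable on this read-out. No measured evidence bears on the reason for this result.

Still open, on these data alone, is whether a different group on this carbon, such as phenyl, cyclohexyl or a pyridine ring, would shift the number beyond the scatter. As far as these compounds go, it is also open whether thiophen-2-yl and furan-2-yl would stay indistinguishable with the propyl group of compound 1 on the oxygen next to the carbonyl group.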